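Second fluoro on the phenyl ring: permeability outlook

The source may report more compounds than this note shows. Statements on the series, on what has been measured and on what is new or still open speak of the compounds shown alone.

The series shares the core of compound 1 `Cc1cc(NC(=O)Nc2ccccc2F)c2ccccc2n1`, a urea linking it to a fluorophenyl ring. In an ADME assay for permeability, using PAMPA, at pH 7.4 (a lower number here means that the compound crosses the layer more slowly, a higher number that the compound crosses the layer faster), compound 1 gives 817 10^-6 cm/s. Compound 2 `Cc1cc(NC(=O)Nc2ccc(F)cc2)c2ccccc2n1` gives 801 10^-6 cm/s, and compound 3 `COC(=O)c1ccc(NC(=O)Nc2cc(C)nc3ccccc23)cc1` gives 448 10^-6 cm/s. Compound 2 stands second highest of the three numbers in this assay; its nearest neighbour is compound 1, with a 1.0-fold lower number from compound 1 to compound 2 (0.01 log units; within the scatter), and its furthest is compound 3, with a 1.8-fold lower number from compound 2 to compound 3 (0.25 log units; within the scatter), so all three sit within the scatter of one another.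

Compound 4 `Cc1cc(NC(=O)Nc2ccc(F)cc2F)c2ccccc2n1` is not yet measured. It differs from compound 2 by fluoro in place of hydrogen on an aromatic carbon.

Both known steps bear on the fluorophenyl ring: moving the fluoro gave a 1.0-fold lower number from compound 1 to compound 2 (0.01 log units; within the scatter), and exchanging it for methoxycarbonyl gave a 1.8-fold lower number from compound 2 to compound 3 (0.25 log units; within the scatter). Neither step left the scatter. Among the compounds with values here, no measured pair adds a second fluoro, so the expectation rests on these small movements: compound 4 is expected to show a 1.0-fold lower number from compound 2 to compound 4 (0.01 log units; within the scatter), nothing beyond the scatter. Compound 4 is estimated at 790 10^-6 cm/s, expected between 480 10^-6 cm/s and 1250 10^-6 cm/s.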

Compound 4, apparent permeability: 640 10^-6 cm/s
Compound 4: middle estimate off by 1.2-fold (0.09 log units), on the high side, and the stated range covers the measured number.
By their numbers in this assay, from the lowest: compounds 3, 4, 2 and 1 (each within the scatter of the next).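

A second fluoro on the ring, ortho to a large group and meta to a fluoro group, is tolerated at this position in this assay: the step from the 4-fluorophenyl compound reads (a 1.3-fold lower number from compound 2 to compound 4 (0.10 log units; within the scatter)), and the step from the 2-fluorophenyl compound reads (a 1.3-fold lower number from compound 1 to compound 4 (0.11 log units; within the scatter)). Both steps stay within the scatter, so the earlier pattern of small movements, seen until now only with a single substituent on this ring, also holds for a ring carrying two fluoro groups. No measurement available here gives a reason for this result.

On these data alone, whether a methoxy group, an amine or a carboxylic acid at this same position would also stay within the scatter remains open. A third fluoro on the ring is equally unresolved.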